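From 4-propylphenyl to 2-methoxyphenyl on the amide

The source may report more compounds than this note shows. Statements on the series, on what has been measured and on what is new or still open speak of the compounds shown alone.

Measured in a functional assay on HepG2 cells (Homo sapiens) for inhibition, read by MTT assay, with a stated time of 72 h; on this read-out higher numbers stand for weaker inhibition and lower numbers for stronger inhibition:
- compound 1 `CCCc1ccc(NC(=O)C2CCN(C/C=C/c3ccccc3)CC2)cc1`: 9410 nM
- compound 2 `CCCCc1ccc(NC(=O)C2CCN(C/C=C/c3ccccc3)CC2)cc1`: 4320 nM
- compound 3 `CCCCCc1ccc(NC(=O)C2CCN(C/C=C/c3ccccc3)CC2)cc1`: 2890 nM

Compound 1 gives the highest number of the three, which makes it the weakest inhibitor of the set. The measured steps away from it are a 2.2-fold lower number from compound 1 to compound 2 (0.34 log units; beyond the scatter) and a 3.3-fold lower number from compound 1 to compound 3 (0.51 log units; beyond the scatter), both modest. The remaining step, a 1.5-fold lower number from compound 2 to compound 3 (0.17 log units; within the scatter), stays within the scatter. All three steps only lengthen the alkyl chain.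

Compound 4 `COc1ccccc1NC(=O)C1CCN(C/C=C/c2ccccc2)CC1` differs from compound 1 in a larger way: 2-methoxyphenyl in place of 4-propylphenyl on an amide-type nitrogen. In words, it carries 2-methoxyphenyl in place of 4-propylphenyl on an amide-type nitrogen. Going by the values given here, no measured step removes the chain altogether or introduces a methoxy group, so the evidence is indirect. Read in reverse, a 2.2-fold lower number from compound 1 to compound 2 (0.34 log units; beyond the scatter) suggests that losing chain length moves the number upward, and compound 1 already has the shortest chain measured. A modest step towards weaker inhibition in this assay is therefore expected, of about the measured size, though with wide uncertainty.

The expected change is a 2.1-fold higher number from compound 1 to compound 4 (0.33 log units; beyond the scatter). For compound 4 the estimated value is 20000 nM, with an expected range from 8000 nM to 50000 nM.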

Compound 4, half-maximal inhibitory concentration: 91200 nM
Compound 4: middle estimate off by 4.6-fold (0.66 log units), on the low side; the measured number lies above the stated range.
By their numbers in this assay, from the lowest: compounds 3 and 2 (each within the scatter of the next); then compound 1; then compound 4.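

In this assay the exchange of 4-propylphenyl for 2-methoxyphenyl on the amide-type nitrogen gives a 9.7-fold higher number from compound 1 to compound 4 (0.99 log units; beyond the scatter) and so runs against the direction of the chain steps, the largest of which is a 3.3-fold lower number from compound 1 to compound 3 (0.51 log units; beyond the scatter) in this series. The earlier compounds shown here showed this position only through changes in alkyl chain length, all of which lowered the number, whereas compound 4 shows that replacing the whole group can raise it, and by more than any chain step moved it. Nothing measured here accounts for the size of this rise.

Since compound 4 both loses the propyl chain and gains the methoxy group, the step from compound 1 cannot assign the rise to either change alone, and a plain phenyl group on the same nitrogen would be the comparison that separates them. Also open, going by these compounds, is how a hydroxyl group in place of the methoxy group would read on this scale, and whether a hexyl chain would lower the number any further, given that the last chain step, a 1.5-fold lower number from compound 2 to compound 3 (0.17 log units; within the scatter), stays within the scatter.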